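From Thiazole to Isoxazole on a Shared Core

The source may report more compounds than this note shows. Statements on the series, on what has been measured and on what is new or still open speak of the compounds shown alone.

Compound 1 `CCc1c(OC)nc2nc(-c3nc(C)cs3)cn2c1C` is the reference point of this small set. In a functional assay on the whole organism with Rattus norvegicus as the target (on this read-out higher numbers stand for an effect only at larger amounts of compound and lower numbers for an effect already at smaller amounts), compound 1 reaches only a limit of the assay, > 50 mg/kg. Compound 2 `CCc1c(SC)nc2nc(-c3nc(C)cs3)cn2c1C` likewise reaches only a limit in this assay, > 50 mg/kg. Compound 3 `CCOC(=O)c1csc(-c2cn3c(C)c(CC)c(OC)nc3n2)n1` also ends at a limit, > 50 mg/kg. The two measured steps, a step that the two limits leave unreadable from compound 1 to compound 2 and a step that the two limits leave unreadable from compound 1 to compound 3, are therefore unreadable in size, and every value shown sits at one limit (the limit of > 50 mg/kg in this assay, at which 3 of the 3 values shown sit). Compound 4 `CCc1c(OC)nc2nc(-c3cc(C)no3)cn2c1C` differs from compound 1 by 3-methyl-1,2-oxazol-5-yl in place of 4-methyl-1,3-thiazol-2-yl on an aromatic carbon. Within the data shown here, no measured step bears on this exchange, so nothing in the data points to a readable step in either direction. Compound 4 is therefore expected to give 50 mg/kg, with a range from 15 mg/kg to 150 mg/kg, which means an expected step of a number no higher from compound 1 to compound 4 (the limit leaves the size open), most probably ending at another limit.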

Compound 4, minimum effective dose: 50 mg/kg
Estimate against measurement, compound 4: no gap at the digits printed; the measured number falls inside the stated range.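

In this assay, putting 3-methyl-1,2-oxazol-5-yl in place of 4-methyl-1,3-thiazol-2-yl gives a number no higher from compound 1 to compound 4 (the limit leaves the size open). This change on an aromatic carbon of the shared core thus yields a readable number, which neither the methylsulfanyl nor the ethoxycarbonyl change did, and the other steps cannot be read. Compound 4 alone stands apart from the limit shared by the rest: the limit of > 50 mg/kg in this assay, at which 3 of the 4 values shown sit.

From the compounds shown here alone, how far compound 4 lies from compound 1 remains open. So does the effect of an amine or a carboxylic acid in place of the methyl on 3-methyl-1,2-oxazol-5-yl.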